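Piperidine in Place of Dimethylamine: Solubility Outlook

The source may hold more compounds than are shown below. What is called first, only, known or untested is meant among the compounds shown, and "the series" means these compounds.

Compound 1, `[O-][n+]1nc(NCCN2CCCCC2)[n+]([O-])c2cc(Cl)ccc21`, in a physicochemical assay for solubility, in the presence of a further agent that is not named here (on this read-out higher numbers stand for higher solubility and lower numbers for lower solubility), gives 3200000 nM.
Compound 2, `CN(C)CCNc1n[n+]([O-])c2ccc(C(C)(C)C)cc2[n+]1[O-]`, in this assay gives 38000000 nM.

Of the two numbers, compound 2 stands highest; its gap to compound 1 lies beyond the scatter of repeated measurements. Compound 3, `CC(C)(C)c1ccc2c(c1)[n+]([O-])c(NCCN1CCCCC1)n[n+]2[O-]`, has not yet been measured. It differs from compound 2 in a single place: piperidin-1-yl in place of dimethylamino on a saturated chain carbon, two bonds along the chain from a nitrogen on an aromatic ring. Among the compounds with values here, no pair of measured compounds shows this change on its own. Within the data shown here, compound 1 does carry the piperidin-1-yl group, but it differs from compound 2 in other places as well, so the two values show only their own gap and give no step for this change. The step from compound 2 to compound 3 is expected to be small and downward, at most a little beyond the scatter, namely a 1.9-fold lower number from compound 2 to compound 3 (0.28 log units; within the scatter). Compound 3 is accordingly estimated at 20000000 nM in this assay, with a range from 5000000 nM to 60000000 nM.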

Compound 3, solubility: 28000000 nM
Estimate against measurement, compound 3: 1.4-fold (0.15 log units) below, within the range that was stated.
By their numbers in this assay, from the lowest: compound 1; then compounds 3 and 2 (each within the scatter of the next).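

Compound 3 gives piperidin-1-yl in place of dimethylamino a step of its own at this place on a saturated chain carbon, and in this assay that step is a 1.4-fold lower number from compound 2 to compound 3 (0.13 log units; within the scatter), so the two groups cannot be told apart here. It also isolates tert-butyl in place of chloro on an aromatic carbon, with an 8.8-fold higher number from compound 1 to compound 3 (0.94 log units; beyond the scatter), so of the two single changes now readable, only this one lies beyond the scatter. Nothing shown offers a reason for either step.

From the compounds shown here alone, it remains open whether a morpholine ring or a longer chain at the chain position would also stay within the scatter of compound 2 in this assay. The compounds also leave open how a methoxy group or a carboxylic acid would read in place of tert-butyl on the aromatic carbon.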